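Ethoxy for ethyl on the aryl ring of compound 1

A few compounds are considered here, and "the series" means these few. Any claim that something is new, unique, unknown or untested is made for them only; others in the source may bear on it.

Measured compounds:
- compound 1, `CCc1ccc(-c2nn3cc(-c4cccc(N)c4)nc3s2)cc1`: 8100 nM in a functional assay on HeLa cells (Homo sapiens) for inhibition, read by cell counting, with a stated time of 4 days; on this read-out higher numbers stand for weaker inhibition and lower numbers for stronger inhibition
- compound 2, `C=C(Br)C(=O)Nc1cccc(-c2cn3nc(-c4ccc(CC)cc4)sc3n2)c1`: 3200 nM in this assay

Compound 1 gives the highest of the two numbers in this assay; its nearest neighbour is compound 2, reached by a 2.5-fold lower number from compound 1 to compound 2 (0.40 log units; beyond the scatter), a modest step that lies beyond the scatter and comes from the (1-bromoethenyl)carbonyl group in place of hydrogen on a nitrogen on an aromatic ring.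

Compound 3, `CCOc1ccc(-c2nn3cc(-c4cccc(N)c4)nc3s2)cc1`, differs from compound 1 elsewhere: ethoxy in place of ethyl on an aromatic carbon. Within the data shown here, no measured step touches this ring or this group, so the one step on record, which concerns the aromatic nitrogen, does not bear on it directly. With nothing to point either way, the expected change in this assay from compound 1 to compound 3 is none beyond the scatter, that is a 1.0-fold lower number from compound 1 to compound 3 (0.01 log units; within the scatter). Compound 3 is therefore estimated at 8000 nM, within 3000 nM to 20000 nM.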

Compound 3, half-maximal inhibitory concentration: 94000 nM
For compound 3 the middle estimate is 12-fold (1.07 log units) below the measured one; the measured number lies above the stated range.
By their numbers in this assay, from the lowest: compound 2; then compound 1; then compound 3.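

In this assay, among these compounds, the ethoxy in place of ethyl on an aromatic carbon gives a 12-fold higher number from compound 1 to compound 3 (1.06 log units; beyond the scatter), a large step that shows weaker inhibition and is the first measured change at this place, para to a large group. It runs opposite in direction to a 2.5-fold lower number from compound 1 to compound 2 (0.40 log units; beyond the scatter) and is larger, so the substituent on this ring matters at least as much here as the group on the nitrogen, and swapping ethyl for ethoxy, which brings in one oxygen and one hydrogen-bond acceptor, is not a neutral change. Nothing available here accounts for this shift.

The compounds shown leave open whether a methoxy group, a propyl chain or an amine at this place would follow ethoxy or ethyl. They also leave open whether the (1-bromoethenyl)carbonyl group on the nitrogen would lower the number on the ethoxy compound as it does on the ethyl one.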